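A Second Hydroxy Added to Two Related Cores

The source may hold more compounds than are shown below. What is called first, only, known or untested is meant among the compounds shown, and "the series" means these compounds.

Compound 1, `O=c1cc(/C=C/c2ccc(O)cc2)oc2cc(O)ccc12`: 1400 nM
Compound 2, `O=c1cc(/C=C/c2ccc(O)c(O)c2)oc2cc(O)ccc12`: 300 nM
Compound 3, `O=c1cc(/C=C/c2ccc(O)cc2)oc2cccc(O)c12`: 1040 nM

These three compounds have been tested in a functional assay, in the absence of a further agent; on this read-out higher numbers stand for weaker inhibition and lower numbers for stronger inhibition. Compound 1 and compound 3 are built from the same atoms joined differently; the difference between the two cores is not broken down here. In this assay the values of compound 1 and compound 3 lie within the scatter of each other, so nothing separates them.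

Within the data shown here, the one counted change is hydroxy in place of hydrogen on an aromatic carbon, and it gave a 4.7-fold lower number from compound 1 to compound 2 (0.67 log units; beyond the scatter). Compound 4, `O=c1cc(/C=C/c2ccc(O)c(O)c2)oc2cccc(O)c12`, has not yet been measured; it stands to compound 3 as compound 2 stands to compound 1, through (hydroxy in place of hydrogen on an aromatic carbon), the same change at the same kind of place.

Compound 4 is therefore expected to show a 4.2-fold lower number from compound 3 to compound 4 (0.62 log units; beyond the scatter) in this assay. That expectation rests on a single earlier pair, because a 4.7-fold lower number from compound 1 to compound 2 (0.67 log units; beyond the scatter) followed the identical change, and it is accepted that one pair is a thin basis. Compound 4 is estimated at 250 nM, with a likely range from 100 nM to 700 nM.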

Compound 4, half-maximal inhibitory concentration: 260 nM
The estimate for compound 4 lay 1.0-fold (0.02 log units) below the measured number; low and high end bracket the measured number.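

In this assay, hydroxy in place of hydrogen on an aromatic carbon, ortho to a hydroxy group, gave a 4.0-fold lower number from compound 3 to compound 4 (0.60 log units; beyond the scatter), and the step on this second core matched the one seen on the first: the same change on two cores in this assay, a 4.7-fold lower number (0.67 log units; beyond the scatter) from compound 1 to compound 2 and a 4.0-fold lower number (0.60 log units; beyond the scatter) from compound 3 to compound 4, 1.2-fold (0.07 log units) apart, within the scatter of two such steps. Within this series, then, the change carried from one core to the other with its size intact, even though the two cores are built from the same atoms joined differently. Among these compounds, this rests on only two pairs and does not show that the step would hold on a core of another kind, nor does it explain why the added hydroxy goes with stronger inhibition.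

The compounds shown leave open whether a methoxy group, a fluorine atom or an amine entering at the same place would give a step of similar size. They also leave open whether the step would survive if the neighbouring hydroxy group were itself replaced by methoxy.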